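Swapping the amide aryl group on a sulfonamide series

The source may report more compounds than this note shows. Statements on the series, on what has been measured and on what is new or still open speak of the compounds shown alone.

Three compounds share one core, an amide linked through a central ring to a sulfonamide. In a functional assay on HEK293 cells for agonist activity at probable G-protein coupled receptor 27 (Homo sapiens), read by a luciferase reporter and beta-arrestin recruitment, with a stated time of 10 min (on this read-out higher numbers stand for larger maximal responses and lower numbers for smaller maximal responses), compound 1 `O=C(Nc1ccc(S(=O)(=O)Nc2ccc(Cl)cc2)cc1)c1ccc(Cl)cc1Cl` gives "not determined" (no result reported). Compound 2 `N#Cc1ccc(C(=O)Nc2ccc(S(=O)(=O)Nc3ccccc3)cc2)c(F)c1` gives 29% in this assay. Compound 3 `O=C(Nc1ccc(S(=O)(=O)Nc2ccccc2)cc1)c1ccc2ccccc2c1` gives 115% in this assay. Compound 2 thus stands lowest of the two numbers, and the gap to compound 3 lies beyond the usual scatter, so the amide aryl group clearly matters for the size of the maximal response.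

The next compound, compound 4 `Cc1cc(Br)ccc1C(=O)Nc1ccc(S(=O)(=O)Nc2ccccc2)cc1`, keeps the whole core of compound 2 and changes only the amide aryl group: 4-bromo-2-methylphenyl in place of 4-cyano-2-fluorophenyl on a carbonyl carbon. Among the measured compounds shown here, no measured pair with exactly this exchange exists, so its size must be guessed. Compound 3 shows that a group without a nitrile or fluorine on this carbonyl carbon can reach a large maximal response, because compound 3 gives 115%. An upward step beyond the scatter is therefore expected, though not necessarily one reaching compound 3.

For compound 4 a maximal response of 70% is estimated, with a range from 30% to 110%. This means an expected step of a number 41 percentage points higher from compound 2 to compound 4 (beyond the scatter) in this assay.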

Compound 4, largest response reached (Emax), in percent of the reference or control that the assay uses: 103%
Compound 4: middle estimate off by 33 percentage points, on the low side, within the range that was stated.
By their numbers in this assay, from the lowest: compound 2; then compound 4; then compound 3.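

In this assay, the exchange of 4-cyano-2-fluorophenyl for 4-bromo-2-methylphenyl on a carbonyl carbon gives a number 74 percentage points higher from compound 2 to compound 4 (beyond the scatter), so this single change, with the rest of the molecule unchanged, has a large effect on the maximal response. Both groups contain one six-membered aromatic ring of carbon only, so the presence of that ring does not by itself decide the outcome, and a large response at this position does not depend on the aryl group of compound 3, since compound 4 gives 103%. The data shown include no independent measurement that could explain the size of this step.

The exchange replaces both the nitrile and the fluorine at once, so the share of the step that belongs to each swap, bromine for nitrile or methyl for fluorine, remains unresolved. From the compounds shown here alone, it also remains open how the maximal response would change if this aryl group carried an amine or a carboxylic acid.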